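Swapping hydroxy for amino on a potent compound

The source may hold more compounds than are shown below. What is called first, only, known or untested is meant among the compounds shown, and "the series" means these compounds.

Compound 1 `COc1cc(C(=O)c2ccc(OC)c(O)c2OC)cc(OC)c1O` gives 282 nM in a functional assay on MDA-MB-435 cells (Homo sapiens) for cytotoxicity, read by sulforhodamine B assay, with a stated time of 48 h; a higher number here means a weaker inhibitor of growth, a lower number a stronger inhibitor of growth. Compound 2 `COc1ccc(C(=O)c2cc(OC)c(OC)c(OC)c2)c(OC)c1O` gives < 10 nM in this assay, and this is a limit of the assay, not a number. Going by the values given here, the one measured step is an at least 28-fold lower number from compound 1 to compound 2 (1.45 log units; beyond the scatter), with methyl in place of hydrogen on an oxygen on an aromatic ring.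

Compound 3 `COc1ccc(C(=O)c2cc(OC)c(OC)c(OC)c2)c(OC)c1N` differs from compound 2 in one place. It has amino in place of hydroxy on an aromatic carbon, ortho to two methoxy groups: amino in place of hydroxy on an aromatic carbon. The measured step is a different change, so it sets no size for this one. It does show that one small change on this kind of compound can matter greatly.

With only a limit as the starting point, the expected result in this assay is a number no lower from compound 2 to compound 3 (the limit leaves the size open), probably with nothing beyond the scatter. The expected range reaches further toward higher numbers, given the size of an at least 28-fold lower number from compound 1 to compound 2 (1.45 log units; beyond the scatter). For compound 3 the estimated value is 10 nM, expected to fall between 3 nM and 60 nM.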

Compound 3, concentration for 50% growth inhibition: < 10000 nM
Compound 3 gave a limit, no number; the forecaster's own chance of this, stated with the estimate: 45%; the middle value does not contradict the limit.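

Compound 2 and compound 3 each carry only a limit in this assay, not a number, so the step between them cannot be read. The compounds shown leave open whether amino in place of hydroxy on an aromatic carbon changes growth inhibition at all, in which direction, and by how much.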